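This account rests on a few compounds, and the source may have more. Where it says the series, first, only, none or still open, it means among the compounds named here.

Compound 3 `CC(C)Cn1nnc(CNC(=O)c2ccc(-c3ccccc3)cc2)n1` is the only one of the three measured compounds that returns an actual number in a functional assay on HEK293 cells for agonist activity at transient receptor potential cation channel subfamily V member 1 (Homo sapiens), read by calcium flux; on this read-out lower numbers stand for an effect already at smaller amounts and higher numbers for an effect only at larger amounts of compound: compound 3 gives 53500 nM. Compound 1 `CN(C)C(=O)Cn1nnc(CNC(=O)c2ccc(-c3ccccc3)cc2)n1` reaches only a limit of the assay, with > 100000 nM. Compound 2 `CC(=O)Cn1nnc(CNC(=O)c2ccc(-c3ccccc3)cc2)n1` likewise stops at a limit, with > 100000 nM. Both of these sit at the limit of > 100000 nM in this assay, at which 2 of the 3 values shown sit. Measured against those limits, the results show an at least 1.8-fold lower number from compound 1 to compound 3 (0.27 log units; that floor lies within the scatter) and an at least 1.8-fold lower number from compound 2 to compound 3 (0.27 log units; that floor lies within the scatter); each is a floor, and each floor lies within the scatter, so the true size of either step is not known.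

Compound 4 `COC(=O)Cn1nnc(CNC(=O)c2ccc(-c3ccccc3)cc2)n1` has not yet been measured. It differs from compound 3 by methoxycarbonyl in place of isopropyl on a saturated chain carbon bound to an aromatic nitrogen. That change runs opposite to the two measured steps, in which a carbonyl-bearing group gave way to isopropyl; here a carbonyl-bearing group enters in place of isopropyl. The expectation in this assay is accordingly a step of a 1.9-fold higher number from compound 3 to compound 4 (0.27 log units; within the scatter) toward a higher number, with a fair chance that the assay again reports only a limit. Compound 4 is estimated at 100000 nM, in the range 40000 nM to 250000 nM.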

Compound 4, half-maximal effective concentration: > 100000 nM
Compound 4: no number, only a limit (the forecaster's own chance of this, stated with the estimate: 60%); the middle value lies on the limit itself.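

With methoxycarbonyl in place of isopropyl on a saturated chain carbon bound to an aromatic nitrogen, this assay shows an at least 1.8-fold higher number from compound 3 to compound 4 (0.27 log units; that floor lies within the scatter), a floor that leaves the true size of the step unknown. A third carbonyl-bearing group now stops at the assay limit, so compound 1, compound 2 and compound 4 all lack a number, and among these four compounds only compound 3, with its isopropyl, returns one: the limit of > 100000 nM in this assay, at which 3 of the 4 values shown sit. The steps among compound 1, compound 2 and compound 4 cannot be read, as each joins two limits.

From the compounds shown here alone, whether methoxy, methyl and dimethylamino on the carbonyl carbon differ at all therefore stays open. Going by these compounds, it is also open whether a longer carbon chain at this place would give a lower number than compound 3, or whether an amine or a carboxylic acid there would return a number at all.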